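This account rests on a few compounds, and the source may have more. Where it says the series, first, only, none or still open, it means among the compounds named here.

Measured so far:
compound 1 `Nc1scc(CN2CCN(c3ccc(Cl)cc3Cl)CC2)c1C(=O)c1ccc(Cl)cc1` — in an assay on CHO cells for displacement of a labelled ligand from adenosine receptor A3 (Homo sapiens), read by scintillation counting, with a stated time of 120 min, tested at 10 uM (a lower number here means less inhibition, a higher number more inhibition at the concentration tested (going by the name of the read-out)), compound 1 gives 0%
compound 2 `Nc1scc(CN2CCN(c3ccc(F)cc3Cl)CC2)c1C(=O)c1ccc(Cl)cc1` — in this assay compound 2 gives 0%
compound 3 `Nc1scc(CN2CCN(C3CCCCCC3)CC2)c1C(=O)c1ccc(Cl)cc1` — in this assay compound 3 gives 0%

Compound 3 stands level with compound 1 and compound 2; the whole set sits at the floor of the read-out, and no change at the digits printed from compound 1 to compound 2 (within the scatter) is also flat.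

Compound 4 `Nc1scc(CN2CCN(c3c(F)cccc3F)CC2)c1C(=O)c1ccc(Cl)cc1` is not yet measured. Its change from compound 3 is 2,6-difluorophenyl in place of cycloheptyl on an amine nitrogen in a ring. Within the data shown here, the steps that bear on it are no change at the digits printed from compound 1 to compound 3 (within the scatter) and no change at the digits printed from compound 2 to compound 3 (within the scatter), which exchange a group on the same ring nitrogen and show no movement; nothing in the data moves in this assay at all. A flat step is therefore expected, no change at the digits printed from compound 3 to compound 4 (within the scatter). Compound 4 is expected to give 0%, estimated within 0% to 10%.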

Compound 4, a percentage reported as inhibition, at one concentration (the size of the read-out at that concentration, not a potency): 4%
For compound 4 the middle estimate is 4 percentage points below the measured one; the range from low to high includes it.
By their numbers in this assay, from the lowest: compounds 1, 2, 3 and 4 (each within the scatter of the next).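

In this assay, the change to 2,6-difluorophenyl on the ring nitrogen gives a number 4 percentage points higher from compound 3 to compound 4 (within the scatter), a number 4 percentage points higher from compound 2 to compound 4 (within the scatter) and a number 4 percentage points higher from compound 1 to compound 4 (within the scatter). A phenyl bearing only fluorines therefore stays level with the chlorinated phenyls and cycloheptyl at this position. Nothing available bears on why this position stays flat.

Still open, as far as these compounds go, is whether a benzyl group or a chain ending in a carboxylic acid on this nitrogen would lift the number clear of the scatter. Also open, from the compounds shown here alone, is whether any change elsewhere on the shared core would do so.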